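Removing the isopropyl group from a chalcone-type series

The source may report more compounds than this note shows. Statements on the series, on what has been measured and on what is new or still open speak of the compounds shown alone.

Of the compounds shown here, three sharing one core have been measured in a functional assay on DU-145 cells (Homo sapiens) for antiproliferative activity, read by MTT assay, with a stated time of 72 h; on this read-out lower numbers stand for stronger inhibition and higher numbers for weaker inhibition. Compound 1 `O=C(COc1ccc(C(=O)/C=C/c2ccc(F)c(F)c2)cc1)N[C@H]1CCOC1=O` gives 19800 nM. Compound 2 `O=C(COc1ccc(C(=O)/C=C/c2ccc(F)cc2)cc1)N[C@H]1CCOC1=O` gives 18800 nM, and compound 3 `CC(C)c1ccc(/C=C/C(=O)c2ccc(OCC(=O)N[C@H]3CCOC3=O)cc2)cc1` gives 13100 nM. The step of a 1.1-fold lower number from compound 1 to compound 2 (0.02 log units; within the scatter) swaps one fluoro for hydrogen, the step of a 1.4-fold lower number from compound 2 to compound 3 (0.16 log units; within the scatter) swaps fluoro for isopropyl, and the step of a 1.5-fold lower number from compound 1 to compound 3 (0.18 log units; within the scatter) replaces the whole difluorophenyl group; all three fall within the scatter. Compound 3 thus shows the lowest number of the three, but the other two sit within scatter of it, so no order among them is established.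

Compound 4 `O=C(COc1ccc(C(=O)/C=C/c2ccccc2)cc1)N[C@H]1CCOC1=O` differs from compound 3 by hydrogen in place of isopropyl on an aromatic carbon. Within the data shown here, the steps that bear on this are the aromatic substituent changes from compound 1 to compound 2 and from compound 2 to compound 3, both within the scatter, so no step beyond the scatter is expected in this assay. Compound 4 is therefore estimated at 17000 nM, with a range from 8000 nM to 36000 nM. That amounts to an expected step of a 1.3-fold higher number from compound 3 to compound 4 (0.11 log units; within the scatter).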

Compound 4, half-maximal inhibitory concentration: 48300 nM
The estimate for compound 4 lay 2.8-fold (0.45 log units) below the measured number, and the stated range ends below it.
By their numbers in this assay, from the lowest: compounds 3, 2 and 1 (each within the scatter of the next); then compound 4.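

In this assay, among these compounds, the ring position para to a large group now proves to matter: removing the isopropyl group gives a 3.7-fold higher number from compound 3 to compound 4 (0.57 log units; beyond the scatter) and is the first step beyond the scatter. Replacing the fluoro of compound 2 with hydrogen gives a 2.6-fold higher number from compound 2 to compound 4 (0.41 log units; beyond the scatter) and changing 3,4-difluorophenyl to phenyl gives a 2.4-fold higher number from compound 1 to compound 4 (0.39 log units; beyond the scatter) as well. Compound 4, with a bare phenyl, thus stands as the weakest of the four, while the three compounds carrying a group on this ring stay within the scatter of one another.

No measurement at hand explains this gap. On these data alone, whether an amine, a carboxylic acid or a longer chain in this place would stay level with those three compounds or fall toward compound 4 remains open.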